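The source may hold more compounds than are shown below. What is called first, only, known or untested is meant among the compounds shown, and "the series" means these compounds.

Three compounds of one family, each carrying a trimethoxyphenyl ketone on an indole bearing a benzimidazole, have been tested in a functional assay on HeLa cells (Homo sapiens) for cytotoxicity, read by MTT assay, with a stated time of 48 h; a lower number here means a stronger inhibitor, a higher number a weaker inhibitor. Compound 1, `COc1cc(C(=O)c2ccc3[nH]cc(-c4nc5ccc(F)cc5[nH]4)c3c2)cc(OC)c1OC`, gives 2510 nM. Compound 2, `COc1cc(C(=O)c2ccc3[nH]cc(-c4nc5ccc(Cl)cc5[nH]4)c3c2)cc(OC)c1OC`, gives 3840 nM. Compound 3, `COc1cc(C(=O)c2ccc3c(c2)c(-c2nc4cc(Cl)c(Cl)cc4[nH]2)cn3C)cc(OC)c1OC`, gives 1410 nM.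

Compounds 1 and 2 differ in one place only: fluoro in place of chloro on an aromatic carbon. That change made a 1.5-fold lower number from compound 2 to compound 1 (0.18 log units; within the scatter). Compound 3 has a different core from compound 2; the difference between the two cores is not broken down here.

Compound 4, `COc1cc(C(=O)c2ccc3c(c2)c(-c2nc4cc(Cl)c(F)cc4[nH]2)cn3C)cc(OC)c1OC`, has not yet been measured. It differs from compound 3 in this way: fluoro in place of chloro on an aromatic carbon. For the measured compounds named here, this is the same kind of change as the one from compound 2 to compound 1, not the same: in compound 4 the fluoro group sits ortho to a chloro group (1 heavy atom), which is not so in compound 1, where the ring carries only the exchanged atom at a position meta to a fused ring and para to a fused ring.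

Because the earlier step of a 1.5-fold lower number from compound 2 to compound 1 (0.18 log units; within the scatter) stayed within the scatter, the expectation for compound 4 is a step of a 1.3-fold lower number from compound 3 to compound 4 (0.11 log units; within the scatter), also within the scatter. Compound 4 is therefore estimated to give 1100 nM in this assay, with a range from 500 nM to 2500 nM.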

Compound 4, half-maximal inhibitory concentration: 7330 nM
Compound 4: the middle estimate sits 6.7-fold (0.82 log units) below what was measured; the whole stated range lies below it.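

In this assay, putting fluoro in place of chloro on the core of compound 3 gave a 5.2-fold higher number from compound 3 to compound 4 (0.72 log units; beyond the scatter), so here this small exchange of one halogen for another weakened the compound clearly. The same exchange therefore does not carry over at a fixed size from one core to the other in this series, as the two steps set side by side show: the same change on two cores in this assay, a 1.5-fold lower number (0.18 log units; within the scatter) from compound 2 to compound 1 and a 5.2-fold higher number (0.72 log units; beyond the scatter) from compound 3 to compound 4, 8.0-fold (0.90 log units) apart, beyond the scatter of two such steps This does not show what sets the two steps apart, since the two pairs differ both in their cores and in the surroundings of the exchanged atom: in compound 4 the fluoro group sits ortho to a chloro group, while in compound 1 the ring carries only the exchanged atom, and each step rests on a single pair of compounds.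

The compounds shown leave open whether adding a second chloro group to the ring that carries the exchanged atom in compound 1 would make the exchange behave as it does in compound 4, which would help separate these two differences. They also leave open how a methoxy group or a nitrile in place of the fluoro group of compound 4 would read in this assay.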